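Pyrimidinyl in place of acetylphenyl on a biaryl amide

The compounds below may be only part of what the source reports. "The series", "measured", "known", "first", "only" and "open" are said of these compounds alone.

Compound 1 `COCC(=O)N1CCCc2ccc(NC(=O)c3ccc(-c4ccccc4)cc3)cc21` gives 7.2 in a functional assay for antagonist activity at transient receptor potential cation channel subfamily V member 1 (Homo sapiens), read by FLIPR and calcium flux; on this read-out lower numbers stand for lower potency and higher numbers for higher potency (the scale is a negative logarithm); compound 2 `CC(=O)c1cccc(-c2ccc(C(=O)Nc3ccc4c(c3)N(C)CCC4)cc2)c1` gives 7; compound 3 `CNS(=O)(=O)c1cccc(-c2ccc(C(=O)Nc3ccc4c(c3)N(C)CCC4)cc2)c1` gives 7.

Compound 2 is level with compound 3 and sits with it at the low end of the three numbers, while compound 1 lies within the scatter of both. Compound 4 `CN1CCCc2ccc(NC(=O)c3ccc(-c4cncnc4)cc3)cc21` differs from compound 2 by pyrimidin-5-yl in place of 3-acetylphenyl on an aromatic carbon. Among the measured compounds shown here, only one measured step touches this position, and the step of no change at the digits printed from compound 2 to compound 3 (within the scatter) shows that exchanging one substituent there left the read-out unchanged. Compound 4, however, replaces the whole distal ring rather than a substituent, so a somewhat larger effect is possible. The step of a number 0.30 log units lower from compound 2 to compound 4 (within the scatter) is therefore expected to be small. Compound 4 is estimated at 6.7, with a range from 6.1 to 7.3.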

Compound 4, negative logarithm of the antagonist equilibrium constant: 6.9
The estimate for compound 4 lay 0.20 log units below the measured number; the measured number falls inside the stated range.
By their numbers in this assay, from the lowest: compounds 4, 2, 3 and 1 (each within the scatter of the next).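

In this assay, exchanging the whole ring gives a number 0.10 log units lower from compound 2 to compound 4 (within the scatter). The earlier step showed only that acetyl could be exchanged for methylsulfamoyl on the ring, whereas this one shows that 3-acetylphenyl as a whole can give way to pyrimidin-5-yl, a ring with 2 hetero atoms and no substituent, without a step beyond the scatter. Nothing measured here gives a reason for this result.

The compounds shown leave open whether an amine or a carboxylic acid carried on the pyrimidin-5-yl ring would also stay within the scatter.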